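Replacing Benzyloxy on Compound 3 with a Sulfonylamino Group

The source may report more compounds than this note shows. Statements on the series, on what has been measured and on what is new or still open speak of the compounds shown alone.

Three related compounds have been measured in a functional assay for inhibition, with Homo sapiens as the target (on this read-out higher numbers stand for weaker inhibition and lower numbers for stronger inhibition), so far. Compound 1 (`COc1cc(OC)c(C(=O)/C=C/c2cnccn2)c(OC)c1`) gives 693 nM there, compound 2 (`COc1cccc(C(=O)/C=C/c2ccccc2)c1OC`) gives 1670 nM there, and compound 3 (`O=C(/C=C/c1ccccc1)c1ccccc1OCc1ccccc1`) gives 2230 nM there. Compound 3 therefore stands level with compound 2 within the usual scatter of repeated measurements. Compound 1 shows a lower number, meaning stronger inhibition, by a gap beyond that scatter.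

Compound 4 (`O=C(/C=C/c1ccccc1)c1ccccc1NS(=O)(=O)C(F)(F)F`) has not yet been measured. It carries ((trifluoromethyl)sulfonyl)amino in place of benzyloxy on an aromatic carbon, ortho to a large group (((trifluoromethyl)sulfonyl)amino in place of benzyloxy on an aromatic carbon). Going by the values given here, none of the measured compounds carries this new group, and no measured pair differs in one place only, so the data offer no direct guide and the uncertainty is wide. With compound 3 at 2230 nM as the only anchor, no shift beyond the scatter is expected. The expected step of a 1.4-fold lower number from compound 3 to compound 4 (0.14 log units; within the scatter) stays within the scatter. For compound 4 the estimated value is 1600 nM (expected range 400 nM to 6500 nM).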

Compound 4, half-maximal inhibitory concentration: 5850 nM
Compound 4: middle estimate off by 3.7-fold (0.56 log units), on the low side; the measured number falls inside the stated range.
By their numbers in this assay, from the lowest: compound 1; then compounds 2 and 3 (each within the scatter of the next); then compound 4.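

In this assay, going by these compounds alone, a 2.6-fold higher number from compound 3 to compound 4 (0.42 log units; beyond the scatter) is the only change here that can be read in one place, and it shows that inhibition responds to what sits on this aromatic carbon, with the new group giving the weaker result. The two groups match in heavy-atom count yet differ in kind: benzyloxy brings an aromatic ring of carbon only, whereas ((trifluoromethyl)sulfonyl)amino has no ring and brings a hydrogen-bond donor. No measurement shown here explains which of these differences lies behind the step.

From the compounds shown here alone, it remains open whether the ring of benzyloxy, the trifluoromethyl group or the sulfonylamino link accounts for the step. A methylsulfonylamino group or a plain amine at this place would help separate these parts.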